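This account rests on a few compounds, and the source may have more. Where it says the series, first, only, none or still open, it means among the compounds named here.

Three compounds have so far been measured in an assay on isolated protein for inhibition of Amine oxidase [flavin-containing] A (Homo sapiens), read by fluorescence and Amplex Red, with a stated time of 30 min, tested at 100 uM; a lower number here means a weaker effect, a higher number a stronger effect of the compound at the concentration tested:

compound 1 `CCCCNc1nnc(SCC(=O)N(Cc2cccc([N+](=O)[O-])c2)c2ccc(F)cc2)s1` gives 82.3%
compound 2 `CCCNc1nnc(SCC(=O)N(Cc2cccc([N+](=O)[O-])c2)c2ccc(F)cc2)s1` gives 91.1%
compound 3 `COCCNc1nnc(SCC(=O)N(Cc2cccc([N+](=O)[O-])c2)c2ccc(F)cc2)s1` gives 91.6%

Compound 2 stands second highest of these three numbers. Its nearest neighbour is compound 3, with the step of a number 0.5 percentage points higher from compound 2 to compound 3 (within the scatter); its furthest is compound 1, with the step of a number 8.8 percentage points higher from compound 1 to compound 2 (within the scatter). Both steps sit inside the scatter, so the three compounds cannot be told apart on these numbers.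

Compound 4 `CCNc1nnc(SCC(=O)N(Cc2cccc([N+](=O)[O-])c2)c2ccc(F)cc2)s1` differs from compound 2 in one place: hydrogen in place of methyl on a saturated chain carbon, two bonds along the chain from a nitrogen on an aromatic ring. The step of a number 8.8 percentage points higher from compound 1 to compound 2 (within the scatter) is the same kind of shortening, made one bond further out, and it stayed within the scatter, as did a number 0.5 percentage points higher from compound 2 to compound 3 (within the scatter). No step beyond the scatter in this assay is therefore expected. Compound 4 is expected to give 89%, between 78% and 97%, an expected step of a number 2.1 percentage points lower from compound 2 to compound 4 (within the scatter).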

Compound 4, a percentage reported as inhibition, at one concentration (the size of the read-out at that concentration, not a potency): 89.5%
Compound 4: the middle estimate sits 0.5 percentage points below what was measured, within the range that was stated.
By their numbers in this assay, from the lowest: compounds 1, 4, 2 and 3 (each within the scatter of the next).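

The change from propylamino to ethylamino is a number 1.6 percentage points lower from compound 2 to compound 4 (within the scatter), hydrogen in place of methoxy is a number 2.1 percentage points lower from compound 3 to compound 4 (within the scatter), and hydrogen in place of ethyl is a number 7.2 percentage points higher from compound 1 to compound 4 (within the scatter). So in this assay, the shorter ethylamino chain joins the other chains at this position with no step beyond the scatter, and the four compounds cannot be told apart. Nothing further is available to explain these numbers.

From the compounds shown here alone, whether a carboxylic acid or a longer chain such as octyl here would move the number beyond the scatter stays open. A reading at one concentration also leaves any difference in potency among these compounds open.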